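The source may hold more compounds than are shown below. What is called first, only, known or untested is meant among the compounds shown, and "the series" means these compounds.

Compound 2 `Nc1ccccc1NC(=O)c1ccc(CSC(=S)N2CCN(c3ccc(F)cc3)CC2)cc1` gives 64.5% in a functional assay on HeLa cells (Homo sapiens) for antiproliferative activity, read by CCK-8 assay, with a stated time of 72 h, tested at 8 uM (on this read-out higher numbers stand for a stronger effect at the one concentration tested and lower numbers for a weaker effect), the second highest of three numbers. Compound 3 `CC1CCN(C(=S)SCc2ccc(C(=O)Nc3ccccc3N)cc2)CC1` gives 72.5%, within the scatter of compound 2, while compound 1 `COc1ccc(N2CCN(C(=S)SCc3ccc(C(=O)Nc4ccccc4N)cc3)CC2)cc1` gives 52.3%. Within the data shown here, the only measured step that changes the group carried by the ring nitrogen is a number 12.2 percentage points higher from compound 1 to compound 2 (beyond the scatter), a modest step beyond the scatter. Compound 4 `Nc1ccccc1NC(=O)c1ccc(CSC(=S)N2CCN(c3ncccn3)CC2)cc1` differs from compound 2 by pyrimidin-2-yl in place of 4-fluorophenyl on an amine nitrogen in a ring. Among the measured compounds shown here, no measured step exchanges the aromatic ring itself for one with two hetero atoms, so neither direction is supported by data. Compound 4 is therefore expected to stay close to compound 2, with the step of a number 2.5 percentage points lower from compound 2 to compound 4 (within the scatter) expected to fall within the scatter. The estimate for compound 4 is 62%, ranging from 48% to 76%.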

Compound 4, a percentage reported as inhibition, at one concentration (the size of the read-out at that concentration, not a potency): 73.9%
Compound 4: the middle estimate sits 11.9 percentage points below what was measured; low and high end bracket the measured number.
By their numbers in this assay, from the lowest: compound 1; then compounds 2, 3 and 4 (each within the scatter of the next).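

Among these compounds, on the amine nitrogen in a ring, the earlier compounds compared only aromatic rings of carbon, and compound 4 now brings in one with 2 hetero atoms. In this assay, the exchange for 4-fluorophenyl gives a number 9.4 percentage points higher from compound 2 to compound 4 (within the scatter), so the two groups cannot be told apart, whereas the exchange for 4-methoxyphenyl gives a number 21.6 percentage points higher from compound 1 to compound 4 (beyond the scatter). Nothing available explains either step. The compounds shown leave open how a pyridin-2-yl group or an acetyl group would read at this nitrogen.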